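Thiophen-3-yl in Place of Furan-3-yl: What to Expect

The source may report more compounds than this note shows. Statements on the series, on what has been measured and on what is new or still open speak of the compounds shown alone.

Three compounds have so far been measured in an assay on membranes from HeLa cells for displacement of a labelled ligand from adenosine receptor A3 (Homo sapiens), read by scintillation counting, with a stated time of 180 min, tested at 1 uM; on this read-out higher numbers stand for more inhibition at the one concentration tested (going by the name of the read-out) and lower numbers for less inhibition:

Compound 1 `CC1=C(C(=O)OCC(C)C)C(c2ccoc2)NC(=O)N1`: 16%
Compound 2 `CC1=C(C(=O)OCC(C)C)C(c2ccoc2)NC(=O)N1C`: 16%
Compound 3 `CC1=C(C(=O)OC(C)(C)C)C(c2ccoc2)NC(=O)N1C`: 12%

Compound 2 stands level with compound 1 at the digits shown, and the two share the highest number of the three; compound 3 lies nearest below, with a number 4 percentage points lower from compound 2 to compound 3 (within the scatter). The earlier step, no change at the digits printed from compound 1 to compound 2 (within the scatter), was flat as well. Compound 4 `CC1=C(C(=O)OCC(C)C)C(c2ccsc2)NC(=O)N1C` differs from compound 2 by thiophen-3-yl in place of furan-3-yl on a saturated ring carbon. Neither measured step touches the five-membered aromatic ring on the saturated ring carbon, and both stayed within the scatter, so they offer no direction for this change. A step of no size beyond the scatter is therefore expected, no change at the digits printed from compound 2 to compound 4 (within the scatter). Compound 4 is estimated at 16%, between 6% and 28%.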

Compound 4, a percentage reported as inhibition, at one concentration (the size of the read-out at that concentration, not a potency): 4%
Beside the measured number, compound 4's estimate is 12 percentage points above it; the measured number lies below the stated range.
By their numbers in this assay, from the lowest: compounds 4, 3, 1 and 2 (each within the scatter of the next, the first and the last beyond it).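

In this assay, among these compounds, the five-membered aromatic ring on the saturated ring carbon proves sensitive to change: thiophen-3-yl in place of furan-3-yl gives a number 12 percentage points lower from compound 2 to compound 4 (beyond the scatter), the only step so far beyond the scatter. The two groups match in heavy atoms, hydrogen-bond donors and acceptors, differing in sulfur against oxygen, so those counts do not separate them. Nothing available accounts for the drop.

On these data alone, whether the same swap counts alongside the tert-butyl group of compound 3 or the amide hydrogen of compound 1 stays open. So does how a phenyl ring would read at this place.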